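Ethyl on the Imide Ring of a Piperazine Amide Series

The compounds below may be only part of what the source reports. "The series", "measured", "known", "first", "only" and "open" are said of these compounds alone.

Compound 1: `CC1CC(=O)N(CC(=O)N2CCN(c3ccccc3)CC2)C1=O`, 300 mg/kg
Compound 2: `CCC1(C)CC(=O)N(CC(=O)N2CCN(c3ccc(Cl)cc3)CC2)C1=O`, 100 mg/kg
Compound 3: `Cc1ccccc1N1CCN(C(=O)CN2C(=O)CC(C)C2=O)CC1`, 100 mg/kg

In a functional assay on the whole organism (strain CD1) with Mus musculus as the target, with a stated time of 0.5 h (a lower number here means that less compound is needed, a higher number that more compound is needed for the effect), compound 3 gives 100 mg/kg, level with compound 2 at the digits shown and, with it, the lowest of the three numbers; compound 1 stands highest. Going by the values given here, the single measured step, a 3.0-fold lower number from compound 1 to compound 3 (0.48 log units; beyond the scatter), is modest. Compound 4, `CCC1(C)CC(=O)N(CC(=O)N2CCN(c3ccccc3C)CC2)C1=O`, differs from compound 3 by ethyl in place of hydrogen on a saturated ring carbon. Among the compounds with values here, no measured step isolates this change: compound 2 carries the same ethyl but also differs from compound 1 at the aromatic ring, so their two values alone cannot be split. Compound 4 is therefore expected to stay close to compound 3, with no change at the digits printed from compound 3 to compound 4 (within the scatter), estimated at 100 mg/kg (range 30 mg/kg to 300 mg/kg).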

Compound 4, minimum effective dose: 100 mg/kg
The estimate for compound 4 equals the measured number at the digits printed, within the range that was stated.
By their numbers in this assay, from the lowest: compounds 2, 3 and 4 (each within the scatter of the next); then compound 1.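

In this assay, going by these compounds alone, ethyl in place of hydrogen on the saturated ring carbon, read alone for the first time, gives no change at the digits printed from compound 3 to compound 4 (within the scatter), so this position carries the added ethyl without a measurable shift. With that ethyl present, 2-methylphenyl in place of 4-chlorophenyl gives no change at the digits printed from compound 2 to compound 4 (within the scatter), so these two aryl groups cannot be told apart here. No available evidence bears on these results.

The compounds shown leave open whether a longer chain such as propyl, or an amine or a hydroxyl, at this ring carbon would move the number. They also leave open how the ethyl step reads with other aryl groups on the amine nitrogen.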